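Solubility expected to fall from compound 1 to compound 4

This account rests on a few compounds, and the source may have more. Where it says the series, first, only, none or still open, it means among the compounds named here.

In a physicochemical assay for solubility, read by LC-MS, in phosphate buffer, with a stated time of 24 h, at pH 7.4 (a lower number here means a less soluble compound, a higher number a more soluble compound), three compounds have results so far.

- Compound 1 (`C[C@@H]1CC(=O)N(c2cnc(NCc3c(F)ccc4c3CCO4)n3cnnc23)C1`) gives 130000 nM
- Compound 2 (`Cc1ncccc1-c1cnc(NCc2c(F)ccc3c2CCO3)c2n[nH]c(=O)n12`) gives < 2000 nM (a limit of the assay, not a number)
- Compound 3 (`CN(C)C(=O)c1cc(-c2cnc(NCc3c(F)ccc4c3CCO4)c3cn[nH]c(=O)c23)n(C)n1`) gives 3000 nM

Compound 1 stands highest of the two true numbers, with 130000 nM as its result. The gap down to compound 3 (3000 nM) lies beyond the usual scatter. Compound 2 is known only as a limit (< 2000 nM).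

Compound 4 (`CN(c1ccn(C)n1)c1cnc(NCc2c(F)ccc3c2CCO3)n2cnnc12`) has not yet been measured. It keeps the core of compound 1 and changes one group on an aromatic carbon: methyl(1-methyl-1H-pyrazol-3-yl)amino in place of 4-methyl-2-oxopyrrolidin-1-yl (methyl(1-methyl-1H-pyrazol-3-yl)amino in place of 4-methyl-2-oxopyrrolidin-1-yl on an aromatic carbon).

Among the measured compounds shown here, no two measured compounds differ in one place only, so no measured step sizes this change directly. The nearest hint is weak, since compound 3 also shows a five-membered aromatic ring and gives 3000 nM on a different core. A fall in this assay beyond the scatter is therefore expected, though probably not all the way to that level. The estimated change (a 6.5-fold lower number from compound 1 to compound 4 (0.81 log units; beyond the scatter)) carries wide uncertainty. For compound 4 the expected value is 20000 nM on a estimated range from 4000 nM to 90000 nM as the likely span.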

Compound 4, solubility: 130000 nM
The estimate for compound 4 lay 6.5-fold (0.81 log units) below the measured number; the whole stated range lies below it.
By their numbers in this assay, from the lowest: compound 3; then compounds 1 and 4 (each within the scatter of the next). At a limit, below all of these: compound 2.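

In this assay, replacing 4-methyl-2-oxopyrrolidin-1-yl with methyl(1-methyl-1H-pyrazol-3-yl)amino on this aromatic carbon gives no change at the digits printed from compound 1 to compound 4 (within the scatter). Among the compounds shown here, this is the first measured step at this position, and it shows that on the core of compound 1, a five-membered non-aromatic ring with a carbonyl and a defined stereocentre can give way to a five-membered aromatic ring with 2 hetero atoms, attached through a methylated nitrogen, without the number moving beyond the scatter. Nothing shown explains why the two groups give matching numbers.

For the compounds shown here, only this one pair of groups has been compared at this position, so it remains open whether a very different group there, such as a simple amine, a carboxylic acid or a longer alkyl chain, would leave the number in the same place. As far as these compounds go, compounds 2 and 3 differ from compound 1 in more than one place, so they give no readable step, and whether this exchange would behave the same way on their cores also stays open.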